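This account rests on a few compounds, and the source may have more. Where it says the series, first, only, none or still open, it means among the compounds named here.

In an assay on Sf9 cells for inhibition of serine/threonine-protein kinase 4 (Homo sapiens), read by luminescence and ADP-Glo, with a stated time of 1 h, in the presence of a further agent that is not named here (on this read-out higher numbers stand for weaker inhibition and lower numbers for stronger inhibition), the measured compounds stand as follows:
compound 1, `CC(C)C1C(=O)N(C)c2cnc(Nc3ccc(S(N)(=O)=O)cc3)nc2N1C`: 254 nM
compound 2, `CN1C(=O)C(c2ccccc2)N(C)c2nc(Nc3ccc(S(N)(=O)=O)cc3)ncc21`: 383 nM
compound 3, `CN1C(=O)C(c2cccc(Cl)c2)N(C)c2nc(Nc3ccc(S(N)(=O)=O)cc3)ncc21`: 989 nM

Compound 3 gives the highest number of the three, with a 2.6-fold higher number from compound 2 to compound 3 (0.41 log units; beyond the scatter) and a 3.9-fold higher number from compound 1 to compound 3 (0.59 log units; beyond the scatter) both beyond the scatter, while a 1.5-fold higher number from compound 1 to compound 2 (0.18 log units; within the scatter) lies within it. Compound 4, `CN1C(=O)C(c2cccc(C(F)(F)F)c2)N(C)c2nc(Nc3ccc(S(N)(=O)=O)cc3)ncc21`, differs from compound 3 by trifluoromethyl in place of chloro on an aromatic carbon. For the measured compounds named here, the one measured step at that aromatic carbon is a 2.6-fold higher number from compound 2 to compound 3 (0.41 log units; beyond the scatter), which already carried the number upward; no measured step exchanges chloro for trifluoromethyl, so the expectation rests on that single step and is uncertain. Compound 4 is expected to stay close to compound 3, with at most a small further rise, giving an estimate of 1300 nM with a range of 500 nM to 3500 nM, a step of a 1.3-fold higher number from compound 3 to compound 4 (0.12 log units; within the scatter).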

Compound 4, half-maximal inhibitory concentration: 2710 nM
Compound 4: the middle estimate sits 2.1-fold (0.32 log units) below what was measured; measured number inside the range.
By their numbers in this assay, from the lowest: compounds 1 and 2 (each within the scatter of the next); then compound 3; then compound 4.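

In this assay the aromatic carbon that already responded to chloro responds again, with a 2.7-fold higher number from compound 3 to compound 4 (0.44 log units; beyond the scatter) as trifluoromethyl replaces chloro, so the two groups are not interchangeable at this position. Set against hydrogen, trifluoromethyl gives a 7.1-fold higher number from compound 2 to compound 4 (0.85 log units; beyond the scatter) and against the isopropyl starting point the change gives an 11-fold higher number from compound 1 to compound 4 (1.03 log units; beyond the scatter) as the first large step in the series. No available evidence bears on what lies behind this rise.

As far as these compounds go, whether an amine or a carboxylic acid on that aromatic carbon would bring the number back down remains open.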